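Swapping cyclohexyl for aminomethyl on a weak aortic inhibitor

A few compounds are considered here, and "the series" means these few. Any claim that something is new, unique, unknown or untested is made for them only; others in the source may bear on it.

Measured so far:
- compound 1 `N#Cc1ccccc1Cn1nc(-c2ccc(CO)o2)c2ccccc21`: 8700 nM
- compound 2 `Fc1ccccc1Cn1nc(-c2ncccn2)c2cccnc21`: 1250 nM
- compound 3 `Nc1nc(-c2nn(Cc3ccccc3F)c3ncccc23)ncc1C1CCCCC1`: 561000 nM

All three compounds were tested in a functional assay (aorta) with Oryctolagus cuniculus as the target; on this read-out higher numbers stand for weaker inhibition and lower numbers for stronger inhibition. Compound 3 has the highest number of the three: its value lies well beyond the scatter above compound 1 and still further above compound 2, so among these three it is the weakest inhibitor.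

Compound 4 `NCc1cnc(-c2nn(Cc3ccccc3F)c3ncccc23)nc1N` is not yet measured. It differs from compound 3 in one place: aminomethyl in place of cyclohexyl on an aromatic carbon.

Among the measured compounds shown here, no step between two measured compounds exists that isolates this exchange, so any expectation rests on the spread of the three values. Compound 2 shares the core of compound 3 but carries no group on its six-membered aromatic ring with two nitrogens; in this assay compound 2 gives 1250 nM. Since compound 4 carries a much smaller group than compound 3 on that ring, a move toward lower numbers is expected, with a step of roughly a 9.4-fold lower number from compound 3 to compound 4 (0.97 log units; beyond the scatter) from compound 3 to compound 4. Compound 4 is estimated at 60000 nM, within 6000 nM to 560000 nM.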

Compound 4, half-maximal inhibitory concentration: 1400000 nM
Compound 4: the middle estimate sits 23-fold (1.37 log units) below what was measured; the measured number lies above the stated range.
By their numbers in this assay, from the lowest: compound 2; then compound 1; then compound 3; then compound 4.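

In this assay, putting aminomethyl in place of cyclohexyl on this aromatic carbon, ortho to an amino group, gives a 2.5-fold higher number from compound 3 to compound 4 (0.40 log units; beyond the scatter), a modest step toward weaker inhibition. At this position, then, a smaller group without a ring that brings a hydrogen-bond donor and acceptor does not lower the number, so a smaller group here does not by itself give stronger inhibition. This single exchange changes size, ring and hydrogen-bonding groups all at once, and no measurement shown here explains the step or separates these changes.

From the compounds shown here alone, it remains open how a plain methyl group or a hydroxymethyl group would read on this carbon, which would help separate size from the amine. A longer chain ending in an amine would show whether the distance of that nitrogen from the aromatic ring matters.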